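Bromophenylthio enones: trihydroxyphenyl to difluorophenyl swap

The compounds below may be only part of what the source reports. "The series", "measured", "known", "first", "only" and "open" are said of these compounds alone.

Measured compounds:
compound 1 `O=C(/C(=C\c1c(O)cc(O)cc1O)Sc1ccc(Br)cc1)c1ccc(Cl)cc1` gives 50000 nM
compound 2 `O=C(/C(=C\c1ccc(F)cc1F)Sc1ccc(Br)cc1)c1ccc(Cl)cc1` gives 1000 nM
compound 3 `Cc1ccc(S/C(=C/c2c(O)cc(O)cc2O)C(=O)c2ccc(Br)cc2)cc1` gives > 100000 nM

In a functional assay on DU-145 cells (Homo sapiens) for inhibition, read by trypan blue exclusion, with a stated time of 96 h (on this read-out higher numbers stand for weaker inhibition of growth and lower numbers for stronger inhibition of growth), compound 1 gives 50000 nM, and compound 2 gives 1000 nM. The change between them is 2,4-difluorophenyl in place of 2,4,6-trihydroxyphenyl on a double-bonded chain carbon bound to a double-bonded chain carbon, and it made a step of a 50-fold lower number from compound 1 to compound 2 (1.70 log units; beyond the scatter). Compound 3 sits at a limit of this assay rather than a number, (the limit of > 100000 nM in this assay, at which 1 of the 3 values shown sits). Compound 4 `Cc1ccc(S/C(=C/c2ccc(F)cc2F)C(=O)c2ccc(Br)cc2)cc1` is not yet measured. How the core of compound 3 differs from that of compound 1 is not broken down here. The change from compound 3 to compound 4 is 2,4-difluorophenyl in place of 2,4,6-trihydroxyphenyl on a double-bonded chain carbon bound to a double-bonded chain carbon, the same change as that from compound 1 to compound 2. For compound 4 a step of an at least 33-fold lower number from compound 3 to compound 4 (1.52 log units; beyond the scatter) is expected in this assay, resting on the step seen from compound 1 to compound 2 a 50-fold lower number from compound 1 to compound 2 (1.70 log units; beyond the scatter). Compound 4 is therefore estimated at 3000 nM, with a range from 800 nM to 30000 nM.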

Compound 4, concentration for 50% growth inhibition: > 100000 nM
Compound 4 ended at the assay's limit; the forecaster's own chance of this, stated with the estimate: 15%; middle value at least 33-fold (1.52 log units) from the limit.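

In this assay compound 3 gives > 100000 nM, a limit and not a number. For the compounds shown here, compound 4 gives > 100000 nM, also a limit, and no step between compound 3 and compound 4 can be read. Still open, from the compounds shown here alone, is whether 2,4-difluorophenyl in place of 2,4,6-trihydroxyphenyl changes growth inhibition at all on the core of compound 3.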